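The source may hold more compounds than are shown below. What is called first, only, known or untested is meant among the compounds shown, and "the series" means these compounds.

Of the compounds shown here, three share a core and have been tested in an ADME assay on HEK293 cells (Homo sapiens) for antiproliferative activity, read by MTT assay, with a stated time of 24 h; a higher number here means a weaker inhibitor, a lower number a stronger inhibitor. Compound 1 `COc1ccc(-c2cc(C(=O)/C=C/c3ccccc3)nc3cc(-c4ccccc4)nn23)cc1OC` gives 64100 nM. Compound 2 `COc1ccc(C(=O)/C=C/c2cc(-c3cc(OC)c(OC)c(OC)c3)n3nc(-c4ccccc4)cc3n2)cc1` gives 79800 nM. Compound 3 `COc1cc(-c2cc(C(=O)/C=C/c3ccc(Cl)cc3)nc3cc(-c4ccccc4)nn23)cc(OC)c1OC` gives 53900 nM, the lowest of the three numbers, though its gaps to compound 1 and to compound 2 both lie within the scatter, so no ordering among them can be claimed. The one single-point step shown, a 1.5-fold lower number from compound 2 to compound 3 (0.17 log units; within the scatter), is itself within the scatter.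

Compound 4 `COc1cc(-c2cc(C(=O)/C=C/c3ccccc3)nc3cc(-c4ccccc4)nn23)cc(OC)c1OC` differs from compound 3 by hydrogen in place of chloro on an aromatic carbon. Going by the values given here, no measured step addresses this exact change. Compound 1 carries the same unsubstituted 2-phenylethenyl group as compound 4 but differs from compound 3 elsewhere, and its value sits close to that of compound 3. On this basis compound 4 is expected to give a step of a 1.1-fold higher number from compound 3 to compound 4 (0.05 log units; within the scatter), that is, none beyond the scatter. The estimate for compound 4 in this assay is 60000 nM, with a range from 35000 nM to 105000 nM.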

Compound 4, half-maximal inhibitory concentration: 44800 nM
Compound 4: the middle estimate sits 1.3-fold (0.13 log units) above what was measured; the range from low to high includes it.
By their numbers in this assay, from the lowest: compounds 4, 3, 1 and 2 (each within the scatter of the next).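

Hydrogen in place of chloro at this position, para to a large group, gives a 1.2-fold lower number from compound 3 to compound 4 (0.08 log units; within the scatter), so in this assay the 4-chlorophenyl and phenyl forms cannot be told apart. The other two changes that lead to compound 4 also stay inside the scatter: methoxy in place of hydrogen on an aromatic carbon gives a 1.4-fold lower number from compound 1 to compound 4 (0.16 log units; within the scatter), and (2-phenylethenyl)carbonyl in place of 2-((4-methoxyphenyl)carbonyl)ethenyl gives a 1.8-fold lower number from compound 2 to compound 4 (0.25 log units; within the scatter). No evidence on hand bears on these results.

On this ring, the compounds shown carry only chloro or hydrogen at this position, so it remains open whether an amine or a carboxylic acid there would shift the number beyond the scatter. As far as these compounds go, it also remains open whether any change to the shared core would do so.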